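Removing the triazole methyl: from compound 3 to compound 4

A few compounds are considered here, and "the series" means these few. Any claim that something is new, unique, unknown or untested is made for them only; others in the source may bear on it.

Of the compounds shown here, three on one shared core have been measured in a functional assay with Alpha-1B adrenergic receptor (Homo sapiens) as the target, read by calcium flux; a higher number here means a larger maximal response, a lower number a smaller maximal response. Compound 3 `Cn1ncnc1-c1ccccc1NCC1=NCCN1` gives 93%, the highest of the three numbers. Compound 2 `CCCCn1ncnc1-c1ccccc1NCC1=NCCN1` gives 83%, and compound 1 `Cc1nc(-c2ccccc2NCC2=NCCN2)n(C)n1` gives 0%. The step of a number 93 percentage points higher from compound 1 to compound 3 (beyond the scatter) came with hydrogen in place of methyl on an aromatic carbon, whereas the step of a number 10 percentage points higher from compound 2 to compound 3 (within the scatter) came with hydrogen in place of propyl on a saturated chain carbon bound to an aromatic nitrogen.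

Compound 4 `c1ccc(-c2nc[nH]n2)c(NCC2=NCCN2)c1` has not yet been measured. It differs from compound 3 in this way: 1H-1,2,4-triazol-3-yl in place of 1-methyl-1H-1,2,4-triazol-5-yl on an aromatic carbon. The step that bears most closely on it is a number 10 percentage points higher from compound 2 to compound 3 (within the scatter), which also changed the group on the five-membered aromatic ring and stayed within the scatter. The large step of a number 93 percentage points higher from compound 1 to compound 3 (beyond the scatter) concerns a methyl on an aromatic carbon, a different place, and is not taken as a guide here. Compound 4 is therefore expected to show a step of a number 8 percentage points lower from compound 3 to compound 4 (within the scatter), within the scatter. The maximal response of compound 4 is estimated at 85%, with a range from 60% to 100%.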

Compound 4, largest response reached (reported as maximal response), in percent of the reference or control that the assay uses: 100%
The estimate for compound 4 lay 15 percentage points below the measured number; low and high end bracket the measured number.
By their numbers in this assay, from the lowest: compound 1; then compounds 2, 3 and 4 (each within the scatter of the next, the first and the last beyond it).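

The exchange of 1-methyl-1H-1,2,4-triazol-5-yl for 1H-1,2,4-triazol-3-yl in this assay brought a number 7 percentage points higher from compound 3 to compound 4 (within the scatter) and so left the maximal response effectively unchanged. Among these compounds, all the earlier compounds carried an alkyl group on a triazole nitrogen, whereas compound 4 carries none, has a hydrogen-bond donor in the entering group, and is attached through a different ring position, yet none of this separates it from compound 3 beyond the scatter. Nothing shown here gives a reason for this outcome.

The compounds shown leave open whether the loss of the methyl and the change of attachment would each have the same outcome alone, as they came in a single step. They also leave open how compound 4 would respond to a methyl, an amine or a carboxylic acid on the triazole carbon that bears methyl in compound 1.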